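The compounds below may be only part of what the source reports. "The series", "measured", "known", "first", "only" and "open" are said of these compounds alone.

Measured so far in a functional assay on IMR-32 cells for inhibition of Voltage-dependent N-type calcium channel subunit alpha-1B (Homo sapiens), read by calcium flux; a lower number here means a stronger inhibitor, a higher number a weaker inhibitor:
compound 1 `CC1=NC(C)=C(C(=O)O)C(c2ccc([N+](=O)[O-])cc2)/C1=C(\O)OC/C=C/c1ccccc1` gives 21000 nM;
compound 2 `CC1=NC(C)=C(C(=O)O)C(c2ccsc2)/C1=C(\O)OC/C=C/c1ccccc1` gives 2900 nM;
compound 3 `CC1=NC(C)=C(C(=O)O)C(c2cccc(Cl)c2)/C1=C(\O)OC/C=C/c1ccc(Cl)cc1` gives 1500 nM.

Compound 3 has the lowest of the three numbers. Its gap to compound 2 lies within the scatter, so the two cannot be ordered; its gap to compound 1 lies beyond it. For the measured compounds named here, the only single-site step among the measured compounds is a 7.2-fold lower number from compound 1 to compound 2 (0.86 log units; beyond the scatter), which concerns the group on the saturated ring carbon and not the ester side chain.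

Compound 4 `CC1=NC(C)=C(C(=O)O)C(c2cccc(Cl)c2)/C1=C(\O)OCC(=O)Nc1ccccc1` differs from compound 3 on that side chain: phenylcarbamoyl in place of 2-(4-chlorophenyl)ethenyl on a saturated chain carbon bound to an oxygen on an unsaturated carbon. Going by the values given here, no measured pair shows the effect of this change, so the expectation rests on the observation that the shared core has kept numbers in a narrow band for compounds 2 and 3. Compound 4 is therefore expected to stay near compound 3, with a wide range to allow for the untested change: estimated 3000 nM, between 800 nM and 12000 nM, a step of a 2.0-fold higher number from compound 3 to compound 4 (0.30 log units; within the scatter).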

Compound 4, half-maximal inhibitory concentration: 28000 nM
Compound 4: the middle estimate sits 9.3-fold (0.97 log units) below what was measured; the measured number lies above the stated range.
By their numbers in this assay, from the lowest: compounds 3 and 2 (each within the scatter of the next); then compounds 1 and 4 (each within the scatter of the next).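

In this assay, replacing 2-(4-chlorophenyl)ethenyl with phenylcarbamoyl gives a 19-fold higher number from compound 3 to compound 4 (1.27 log units; beyond the scatter), which shows that the number is sensitive to the group at this side-chain position. Both groups hold 9 heavy atoms and one six-membered aromatic ring of carbon only, so matching those counts did not keep the number in place; the entering group differs in carrying 1 hydrogen-bond donor and 1 hydrogen-bond acceptor and in having no chlorine. No measurement at hand explains the step.

The compounds shown do not separate the amide from the lost chlorine, a question that (4-chlorophenyl)carbamoyl in the same place could answer. They also leave open whether this step would be the same size with thiophen-3-yl on the saturated ring carbon.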